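A few compounds are considered here, and "the series" means these few. Any claim that something is new, unique, unknown or untested is made for them only; others in the source may bear on it.

Compound 1 `C[C@H](NC(=O)Nc1ccccc1F)c1ccccc1`, compound 2 `C[C@@H](NC(=O)Nc1cccc(F)c1)c1ccccc1` and compound 3 `C[C@H](NC(=O)Nc1cc(F)ccc1F)c1ccccc1` share a urea framework; in an ADME assay on the whole organism with Oryza sativa as the target, tested at 1 uM (a higher number here means a weaker effect of the compound at the concentration tested, a lower number a stronger effect), compound 1 gives 92%, compound 2 gives 95% and compound 3 gives 98%. The difference between the cores of compound 1 and compound 2 is not broken down here. From compound 1 to compound 3 the change is fluoro in place of hydrogen on an aromatic carbon, and in this assay the step is a number 6 percentage points higher from compound 1 to compound 3 (within the scatter). Compound 4 `C[C@@H](NC(=O)Nc1cc(F)cc(F)c1)c1ccccc1`, not yet measured, carries the same kind of change relative to compound 2, namely (fluoro in place of hydrogen on an aromatic carbon); the surroundings differ in that the entering fluoro in compound 3 sits para to a fluoro group, whereas in compound 4 it sits meta to a fluoro group. Since compound 2 gives 95% and the comparable step is a number 6 percentage points higher from compound 1 to compound 3 (within the scatter), a step of about a number 3 percentage points higher from compound 2 to compound 4 (within the scatter) is expected from compound 2 to compound 4 in this assay. Compound 4 is therefore estimated at 98%, with a range of 91% to 100%.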

Compound 4, a percentage reported as activity, at one concentration (the size of the read-out at that concentration, not a potency): 98%
Estimate against measurement, compound 4: no gap at the digits printed; the measured number falls inside the stated range.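

In this assay, fluoro in place of hydrogen on an aromatic carbon gives a number 3 percentage points higher from compound 2 to compound 4 (within the scatter). Set beside the earlier step, this gives no sign that the result of the change depends on which of the two cores carries it: the same change on two cores in this assay, a number 6 percentage points higher (within the scatter) from compound 1 to compound 3 and a number 3 percentage points higher (within the scatter) from compound 2 to compound 4, 3 percentage points apart, within the scatter of two such steps

Both steps lie within the scatter, so the pairs do not show that the change has any real effect on the read-out in either core, and agreement between the two cores is therefore a weak test of transfer; nor do two pairs say how the change would behave on any other core or at other places on the ring.

Fluoro is the only group varied on this ring in the compounds shown, so what a chloro, a methoxy, an amine or a carboxylic acid would do at these places remains open. Among the compounds shown here, also open is how much the difference between the two cores itself contributes to this assay, as no pair here isolates it.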